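This account rests on a few compounds, and the source may have more. Where it says the series, first, only, none or still open, it means among the compounds named here.

In a functional assay (Hippocampus) with Rattus norvegicus as the target (a lower number here means a less potent compound, a higher number a more potent compound, by a factor of ten per unit of this negative logarithm), compound 1 `COC(=O)C1CC2CC1N(C)C2` gives 5.4 and compound 3 `COC(=O)C1CC2CNC1C2` gives 5.5, so these two are level within the scatter. Compound 2 `COC(=O)[C@@H]1C[C@@H]2C[C@H]1N(C)C2` stands higher at 5.9, which leaves compound 3 clearly under that mark. Compound 4 `COC(=O)[C@@H]1C[C@H]2CN[C@@H]1C2` keeps everything that compound 3 has, and only the drawing of its shape in space changes: the two compounds have the same atoms and bonds; at least one stereo element is drawn with a configuration in one of them and without one in the other: 3 of 3 stereo elements differ; a stereocentre at a saturated ring carbon is drawn without a configuration in compound 3 and R in compound 4; a stereocentre at a saturated ring carbon is drawn without a configuration in compound 3 and R in compound 4; a stereocentre at a saturated ring carbon is drawn without a configuration in compound 3 and R in compound 4. Among the measured compounds shown here, two measured steps bear on this. The closest is a number 0.50 log units higher from compound 1 to compound 2 (beyond the scatter), the same kind of change, which goes with the fact that one of compounds 1 and 2 is drawn with a defined configuration and the other without, at the place where they differ. The other, with hydrogen in place of methyl on an amine nitrogen in a ring, is a number 0.10 log units higher from compound 1 to compound 3 (within the scatter), so what was seen with the methyl compounds should carry over to those with hydrogen. An upward step of similar, modest size is therefore expected in this assay, estimated as a number 0.50 log units higher from compound 3 to compound 4 (beyond the scatter). Compound 4 is expected at 6, with an estimated range from 5.5 to 6.5.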

Compound 4, negative logarithm of the half-maximal effective concentration: 6
Compound 4: the middle estimate sits on the measured number at the digits printed; the measured number falls inside the stated range.
By their numbers in this assay, from the lowest: compounds 1 and 3 (each within the scatter of the next); then compounds 2 and 4 (each within the scatter of the next).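

In this assay, the step of a number 0.50 log units higher from compound 3 to compound 4 (beyond the scatter) shows that the gain seen with the methyl compounds also appears on the core with hydrogen on the ring nitrogen, and it goes with: the fact that one of compounds 3 and 4 is drawn with a defined configuration and the other without, at the place where they differ. The swap of methyl for hydrogen can now be read with the configuration defined as well, as a number 0.10 log units higher from compound 2 to compound 4 (within the scatter), so this position tolerates either group in both the defined and undefined pairs. The two readings of that swap agree closely, which makes the change independent of the drawn configuration in these four compounds: the same change on two cores in this assay, a number 0.10 log units higher (within the scatter) from compound 1 to compound 3 and a number 0.10 log units higher (within the scatter) from compound 2 to compound 4, 0.00 log units apart, within the scatter of two such steps.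

As far as these compounds go, what the opposite configuration at these stereocentres would give remains open. So does whether an ethyl or benzyl group on the ring nitrogen, or a carboxylic acid in place of the ester, would keep this level.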